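Para Substituent Change on an Inactive Piperazine Amide

The compounds below may be only part of what the source reports. "The series", "measured", "known", "first", "only" and "open" are said of these compounds alone.

The series is tested in an assay on isolated protein for inhibition of thyroid hormone receptor alpha (Homo sapiens), read by fluorescence polarization; a lower number here means a stronger inhibitor, a higher number a weaker inhibitor. Compound 1, `CS(=O)(=O)c1ccc(C(=O)NCC(=O)N(Cc2ccccc2)Cc2ccccc2)cc1[N+](=O)[O-]`, gives 1700 nM in this assay. Compound 2, `CN(CC(=O)N1CCN(c2ccc(F)cc2)CC1)C(=O)c1ccc(S(C)(=O)=O)c([N+](=O)[O-])c1`, reaches only the limit of the assay, > 60000 nM, and no number. Compound 3, `CC1CCN(C(=O)CCCNC(=O)c2ccc(S(C)(=O)=O)c([N+](=O)[O-])c2)CC1`, likewise stops at the limit > 60000 nM. Compound 2 therefore stands at the weak end of the values shown, and it shares that position with compound 3, since two of the three values sit at the limit of > 60000 nM in this assay, at which 2 of the 3 values shown sit.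

Compound 4, `CN(CC(=O)N1CCN(c2ccc(C(F)(F)F)cc2)CC1)C(=O)c1ccc(S(C)(=O)=O)c([N+](=O)[O-])c1`, differs from compound 2 by trifluoromethyl in place of fluoro on an aromatic carbon; cut one bond further out, the difference reads 4-fluorophenyl to 4-(trifluoromethyl)phenyl. Among the measured compounds shown here, no measured pair in this set isolates such a change, so no measured step is available to guide the expectation, and the starting point is itself only a limit. The author expects the step from compound 2 to compound 4 in this assay to be a number no higher from compound 2 to compound 4 (the limit leaves the size open), that is, no change beyond the scatter. For compound 4 the estimated value in this assay is 60000 nM, within a range from 15000 nM to 250000 nM, with a further limit the most likely outcome.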

Compound 4, half-maximal inhibitory concentration: > 60000 nM
Compound 4: only a limit was reported (the forecaster's own chance of this, stated with the estimate: 75%); the middle value lies on the limit itself.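

Compound 2 and compound 4 both stop at a limit in this assay, not at a number, so no step between them can be read: the limit of > 60000 nM in this assay, at which 3 of the 4 values shown sit.

The compounds shown leave open whether trifluoromethyl in place of fluoro on this aromatic ring changes inhibition at all.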